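The source may report more compounds than this note shows. Statements on the series, on what has been measured and on what is new or still open speak of the compounds shown alone.

Compound 2 `COc1cc(/C=C/C(=O)c2cccc(NC(=O)c3ccccc3)c2)ccc1O` gives 4.57 ug/mL in a functional assay on SiHa cells (Homo sapiens) for inhibition (a higher number here means a weaker inhibitor, a lower number a stronger inhibitor), the lowest of the two numbers in hand, with compound 1 `COc1cc(/C=C/C(=O)c2cccc(NC(=O)c3ccc(Cl)c(Cl)c3)c2)ccc1O` at 25.3 ug/mL. Compound 3 `CCOC(=O)C(=O)Nc1cccc(C(=O)/C=C/c2ccc(O)c(OC)c2)c1` reaches only a limit of this assay, > 50 ug/mL. Compound 4 `COc1cc(/C=C/C(=O)c2cccc(NC(C)=O)c2)ccc1O` differs from compound 2 in one place (methyl in place of phenyl on a carbonyl carbon). Among the measured compounds shown here, two steps bear on this change. Swapping the phenyl on that carbonyl carbon for ethoxycarbonyl gave an at least 10-fold higher number from compound 2 to compound 3 (1.03 log units; beyond the scatter), and swapping 3,4-dichlorophenyl for phenyl gave a 5.5-fold lower number from compound 1 to compound 2 (0.74 log units; beyond the scatter), so the group on this carbonyl carbon clearly moves the number. A methyl also lacks the ring, so a weaker inhibitor is expected, roughly a 3.3-fold higher number from compound 2 to compound 4 (0.52 log units; beyond the scatter). Compound 4 is therefore estimated at 15 ug/mL, within 5 ug/mL to 45 ug/mL.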

Compound 4, half-maximal inhibitory concentration: 15.8 ug/mL
For compound 4 the middle estimate is 1.1-fold (0.02 log units) below the measured one; the measured number falls inside the stated range.
By their numbers in this assay, from the lowest: compound 2; then compounds 4 and 1 (each within the scatter of the next). At a limit, above all of these: compound 3.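

Losing the ring does cost activity in this assay, with a 3.5-fold higher number from compound 2 to compound 4 (0.54 log units; beyond the scatter), yet a ring alone is not enough: methyl and 3,4-dichlorophenyl cannot be told apart, with a 1.6-fold lower number from compound 1 to compound 4 (0.20 log units; within the scatter). Methyl also clearly outperforms ethoxycarbonyl on this carbonyl carbon, with an at least 3.1-fold lower number from compound 3 to compound 4 (0.50 log units; beyond the scatter). That step is only a floor, since the value of compound 3 is a limit: the limit of > 50 ug/mL in this assay, at which 1 of the 4 values shown sits.

Still open, from the compounds shown here alone, is how activity would change between methyl and phenyl, for example with an ethyl or a longer chain. Also open, going by these compounds, is whether a single chlorine on the phenyl would keep the activity of compound 2.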